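The source may report more compounds than this note shows. Statements on the series, on what has been measured and on what is new or still open speak of the compounds shown alone.

Measured so far in an ADME assay on HEK293 cells (Homo sapiens) for cytotoxicity, read by CellTiter-Glo, with a stated time of 72 h; on this read-out lower numbers stand for an effect already at smaller amounts and higher numbers for an effect only at larger amounts of compound:

- Compound 1 `CC(=O)O[C@H]1/C=C/C(C)(C)CC2=C(C)[C@@H](OC(C)=O)[C@]3(C[C@@H](C)C=C3/C=C\1C)O2`: 26000 nM
- Compound 2 `CC1=C2CC(C)(C)/C=C/[C@H](OC(=S)n3ccnc3)/C(C)=C\C3=C[C@H](C)C[C@]3(O2)C1=O`: 26000 nM
- Compound 3 `C/C1=C/C2=C[C@H](C)C[C@@]23O[C@]2(CC(C)(C)[C@@H](O)[C@@H]2C1=O)[C@@H](C)C3=O`: 26000 nM

All three compounds read the same at the digits reported, although they differ from one another in more than one place. Compound 3 therefore stands level with compound 1 and compound 2, and none of the three can be ranked above another.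

Compound 4 `C/C1=C/C2=C[C@H](C)C[C@@]23O[C@]2(CC(C)(C)[C@@H](OC(C)C)[C@@H]2C1=O)[C@@H](C)C3=O` has not yet been measured in this assay. It departs from compound 3 at a single place: isopropyl in place of hydrogen on an oxygen on a saturated carbon. Isopropyl stands in place of hydrogen on an oxygen on a saturated carbon, so that hydroxy becomes isopropoxy.

Among the measured compounds shown here, no pair of measured compounds differs in just one place, so the data give no direct measure of what such a change does. For the measured compounds named here, the only guide is the reading of compound 3 at 26000 nM, shared by the two other compounds despite their different structures. The estimated 1.0-fold lower number from compound 3 to compound 4 (0.02 log units; within the scatter) is expected to stay within the usual scatter, with no clear direction. For compound 4 the expected value is 25000 nM, with an estimated range of 10000 nM to 45000 nM.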

Compound 4, half-maximal effective concentration: 26000 nM
Estimate against measurement, compound 4: 1.0-fold (0.02 log units) below; low and high end bracket the measured number.
By their numbers in this assay, from the lowest: compounds 1, 2, 3 and 4 (each within the scatter of the next).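

Among the compounds shown here, this is the first comparison in the set that isolates one place: in this assay, isopropyl in place of hydrogen on an oxygen on a saturated carbon, which turns hydroxy into isopropoxy, gives no change at the digits printed from compound 3 to compound 4 (within the scatter) for this change. The earlier compounds shown here shared one reading across structures that differ in more than one place, so they could say nothing about any single position. This step shows that, on the core of compound 3, the hydrogen of this hydroxy group can be exchanged for isopropyl with no difference in the reading, and no measurement shown here offers an explanation for that.

On these data alone, it remains open whether the same reading would hold with other groups on this oxygen, such as a longer chain, a chain ending in an amine or one ending in a carboxylic acid. A single step also cannot show whether the same exchange would read alike on another core, or whether changes at other places on this core would do so.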